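The compounds below may be only part of what the source reports. "The series", "measured", "known", "first", "only" and "open" are said of these compounds alone.

In an ADME assay on a cell-free system (plasma, Homo sapiens) for metabolic stability, read by LC-MS (on this read-out higher numbers stand for a longer-lived compound and lower numbers for a shorter-lived compound), compound 2 (`NCc1ccc(C(=O)Nc2ccncc2)cc1-c1cccc(C(=O)OCC2CCCC2)c1`) gives 0.517 h and compound 1 (`CCCOC(=O)c1cccc(-c2cc(C(=O)Nc3ccncc3F)ccc2CN)c1`) gives 0.317 h. These two values lie within the scatter of each other, so neither compound can be said to separate from the other on these numbers. The next compound, compound 3 (`CCCOC(=O)c1cccc(-c2cc(C(=O)Nc3ccncc3)ccc2CN)c1`), departs from compound 2 at the ester: ethyl in place of cyclopentyl on a saturated chain carbon bound to an oxygen next to a carbonyl group. Read one bond further out, this turns cyclopentylmethoxycarbonyl into propoxycarbonyl. Going by the values given here, no pair of measured compounds differs in one place only, so the data offer no direct measure of what such a change does in this assay. Among the compounds with values here, the only guide is compound 1, which also carries propoxycarbonyl and gives 0.317 h. On that basis a small drop is expected, and the expected step, a 1.4-fold lower number from compound 2 to compound 3 (0.16 log units; within the scatter), stays within the usual scatter. For compound 3 the half-life is estimated at 0.36 h, with an expected range of 0.18 h to 0.7 h.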

Compound 3, half-life: 0.3 h
For compound 3 the middle estimate is 1.2-fold (0.08 log units) above the measured one, within the range that was stated.
By their numbers in this assay, from the lowest: compounds 3, 1 and 2 (each within the scatter of the next).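

Going by these compounds alone, compound 3 supplies the first comparisons in this assay that differ in one place only. At the ester, ethyl in place of cyclopentyl on a saturated chain carbon bound to an oxygen next to a carbonyl group gives a 1.7-fold lower number from compound 2 to compound 3 (0.24 log units; within the scatter), so the exchange of cyclopentylmethoxycarbonyl for propoxycarbonyl cannot be told apart from the scatter, and the ring and its extra carbons leave no readable mark on these numbers. With propoxycarbonyl held the same, hydrogen in place of fluoro on an aromatic carbon gives a 1.1-fold lower number from compound 1 to compound 3 (0.02 log units; within the scatter), so this second exchange also leaves no readable mark, and no measurement is at hand that could explain either step.

The compounds shown leave open whether a larger departure at the ester, such as a carboxylic acid, an amide in place of the ester, or a longer chain than propyl, would give a step beyond the scatter in this assay. Going by these compounds, it also remains open whether another group on that aromatic carbon, such as chloro or methoxy, would separate from hydrogen and fluoro.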